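The source may hold more compounds than are shown below. What is called first, only, known or untested is meant among the compounds shown, and "the series" means these compounds.

Three compounds share one core and differ only in the amine carried on the saturated chain three bonds along from an oxygen on an aromatic ring. Compound 1 `COc1cc2c(Nc3ccc(C#N)cc3)ncnc2cc1OCCCN1CCCC1` gives 21800 nM in a functional assay on A549 cells (Homo sapiens) for antiproliferative activity, read by MTT assay, with a stated time of 72 h; on this read-out higher numbers stand for weaker inhibition and lower numbers for stronger inhibition. Compound 2 `COc1cc2c(Nc3ccc(C#N)cc3)ncnc2cc1OCCCN1CCC(O)CC1` gives 29900 nM in this assay, and the step of a 1.4-fold higher number from compound 1 to compound 2 (0.14 log units; within the scatter) stays within the scatter. Compound 3 `COc1cc2c(Nc3ccc(C#N)cc3)ncnc2cc1OCCCN1CCCCC1CCO` reaches only a limit in this assay, > 100000 nM, so its position is known only as lying at the limit of > 100000 nM in this assay, at which 1 of the 3 values shown sits. The steps of an at least 4.5-fold higher number from compound 1 to compound 3 (0.66 log units; beyond the scatter) and an at least 3.3-fold higher number from compound 2 to compound 3 (0.52 log units; beyond the scatter) are both beyond the scatter, so compound 3 stands weakest of the three on the numbers shown.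

Compound 4 `CCOC(=O)C1CCN(CCCOc2cc3ncnc(Nc4ccc(C#N)cc4)c3cc2OC)CC1` has not been measured. Its change from compound 3 is 4-(ethoxycarbonyl)piperidin-1-yl in place of 2-(2-hydroxyethyl)piperidin-1-yl on a saturated chain carbon, three bonds along the chain from an oxygen on an aromatic ring. The measured steps that bear on it are those into compound 3, an at least 4.5-fold higher number from compound 1 to compound 3 (0.66 log units; beyond the scatter) and an at least 3.3-fold higher number from compound 2 to compound 3 (0.52 log units; beyond the scatter), and both point the other way when read from compound 3; compound 2, which also carries a piperidine bearing its substituent at the 4-position, gives 29900 nM. Compound 4 is therefore expected to return to a lower number, a step of about an at least 2.5-fold lower number from compound 3 to compound 4 (0.39 log units; beyond the scatter), with an estimated value of 40000 nM, within a range of 15000 nM to 120000 nM.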

Compound 4, half-maximal inhibitory concentration: 89900 nM
For compound 4 the middle estimate is 2.2-fold (0.35 log units) below the measured one; the range from low to high includes it.
By their numbers in this assay, from the lowest: compounds 1 and 2 (each within the scatter of the next); then compound 4. At a limit, above all of these: compound 3.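

At this place, on a saturated chain carbon, three bonds along the chain from an oxygen on an aromatic ring, the group on the piperidine ring can move the number in this assay: ethoxycarbonyl in place of hydroxy gives a 3.0-fold higher number from compound 2 to compound 4 (0.48 log units; beyond the scatter). Compound 1 and compound 2 had stayed within the scatter of each other, yet the 4-(ethoxycarbonyl)piperidin-1-yl group also separates from the pyrrolidin-1-yl group, with a 4.1-fold higher number from compound 1 to compound 4 (0.62 log units; beyond the scatter). Compound 3 has only a limit, and the reading of an at least 1.1-fold lower number from compound 3 to compound 4 (0.04 log units; that floor lies within the scatter) does not separate compound 4 from it.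

The compounds shown leave open how a carboxylic acid or a primary amide would read in place of the ethyl ester on the same piperidine. They also leave open whether a longer chain to the amine would change these steps.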